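Aryl variation at the shared core: weak inhibition throughout

A few compounds are considered here, and "the series" means these few. Any claim that something is new, unique, unknown or untested is made for them only; others in the source may bear on it.

Measured compounds and values:
Compound 1 `O=Cc1ccc(-c2cn3ccnc3c(-c3ccc4ncn(C5CCCCC5)c4c3)n2)cc1` — 11.6%
Compound 2 `c1ccc2c(-c3cn4ccnc4c(-c4ccc5ncn(C6CCCCC6)c5c4)n3)cccc2c1` — 6.49%
Compound 3 `Fc1ccc(-c2cn3ccnc3c(-c3ccc4ncn(C5CCCCC5)c4c3)n2)cc1` — 9.02%

In a functional assay on ACHN cells (Homo sapiens) for inhibition, read by sulforhodamine B assay, with a stated time of 48 h, tested at 10 uM (a lower number here means less inhibition, a higher number more inhibition at the concentration tested (going by the name of the read-out)), compound 2 gives the lowest of the three numbers, yet every step to it lies within the scatter: a number 5.1 percentage points lower from compound 1 to compound 2 (within the scatter) and a number 2.5 percentage points higher from compound 2 to compound 3 (within the scatter). Likewise a number 2.6 percentage points lower from compound 1 to compound 3 (within the scatter) is within the scatter, so the three measured compounds cannot be ordered on these data.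

Compound 4 `Brc1ccc(-c2cn3ccnc3c(-c3ccc4ncn(C5CCCCC5)c4c3)n2)cc1` is not yet measured. Its change from compound 2 is 4-bromophenyl in place of naphthalen-1-yl on an aromatic carbon. The step that bears most directly on it is a number 2.5 percentage points higher from compound 2 to compound 3 (within the scatter), where a 4-fluorophenyl also replaced naphthalen-1-yl and the number barely moved. The remaining steps, a number 5.1 percentage points lower from compound 1 to compound 2 (within the scatter) and a number 2.6 percentage points lower from compound 1 to compound 3 (within the scatter), show the same picture of an aryl group that can be exchanged without a shift beyond the scatter. No step beyond the scatter is therefore expected in this assay for compound 4, which is estimated at 9%, between 0% and 20%. The expected step is a number 2.5 percentage points higher from compound 2 to compound 4 (within the scatter).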

Compound 4, a percentage reported as inhibition, at one concentration (the size of the read-out at that concentration, not a potency): 21.4%
Compound 4: middle estimate off by 12.4 percentage points, on the low side, outside the stated range (above it).
By their numbers in this assay, from the lowest: compounds 2, 3, 1 and 4 (each within the scatter of the next, the first and the last beyond it).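

In this assay, among the compounds shown here, the steps of a number 14.9 percentage points higher from compound 2 to compound 4 (beyond the scatter) and a number 12.4 percentage points higher from compound 3 to compound 4 (beyond the scatter) are the only ones at this position that lie beyond the scatter, so the aryl group here is not as freely exchangeable as the earlier compounds suggested. Exchanging only the substituent on the phenyl ring, bromo for fluoro, is enough to produce such a step, while a number 9.8 percentage points higher from compound 1 to compound 4 (within the scatter) does not set bromo apart from formyl. Nothing available accounts for the difference between bromo and fluoro.

On these data alone, whether 4-chlorophenyl or 4-iodophenyl would stand with the bromo or the fluoro compound remains open, as does the outcome with an amine or a carboxylic acid on the phenyl ring. Inhibition at a single concentration also leaves the potency of compound 4 open.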